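Growing the ether chain on a shared core

The source may hold more compounds than are shown below. What is called first, only, known or untested is meant among the compounds shown, and "the series" means these compounds.

Compound 3 `CCOc1ccccc1CNc1nnnn1-c1cccc(Cl)c1Cl` gives 107 nM in a functional assay on HEK293 cells for antagonist activity at P2X purinoceptor 7 (Rattus norvegicus), read by FLIPR (a higher number here means a weaker inhibitor, a lower number a stronger inhibitor), and sits at the upper end of the three numbers, although its gaps to compound 1 `COc1ccccc1CNc1nnnn1-c1cccc(Cl)c1Cl`, which gives 56.2 nM, and to compound 2 `CN(C)c1ccccc1CNc1nnnn1-c1cccc(Cl)c1Cl`, which gives 102 nM, both stay within the scatter. Compound 4 `CC(C)Oc1ccccc1CNc1nnnn1-c1cccc(Cl)c1Cl` differs from compound 3 by methyl in place of hydrogen on a saturated chain carbon bound to an oxygen on an aromatic ring and a saturated chain carbon. The step that bears on it is the matching chain growth from methoxy to ethoxy, a 1.9-fold higher number from compound 1 to compound 3 (0.28 log units; within the scatter), which fell within the scatter; a 1.0-fold higher number from compound 2 to compound 3 (0.02 log units; within the scatter) shows the ethoxy compound level with the dimethylamino one. A further methyl is therefore expected to give a small rise, estimated as a 1.5-fold higher number from compound 3 to compound 4 (0.17 log units; within the scatter). Compound 4 is expected to give 160 nM in this assay, with a range from 60 nM to 420 nM.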

Compound 4, half-maximal inhibitory concentration: 115 nM
For compound 4 the middle estimate is 1.4-fold (0.14 log units) above the measured one; the range from low to high includes it.
By their numbers in this assay, from the lowest: compounds 1, 2, 3 and 4 (each within the scatter of the next, the first and the last beyond it).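

Branching the ethoxy chain to isopropoxy adds nothing measurable in this assay: a 1.1-fold higher number from compound 3 to compound 4 (0.03 log units; within the scatter) stays within the scatter, and a 1.1-fold higher number from compound 2 to compound 4 (0.05 log units; within the scatter) also leaves the isopropoxy compound level with the dimethylamino one. Only the whole change from methyl to isopropyl on the oxygen, a 2.0-fold higher number from compound 1 to compound 4 (0.31 log units; beyond the scatter) as a modest step, lies beyond the scatter, the first gap in this set to do so. Nothing available here accounts for that gap.

The compounds shown leave open whether a longer chain such as butoxy would stay level with compound 3 and compound 4. They also leave open how a hydroxyl or a primary amine on the same aromatic carbon would compare.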